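Swapping Bromine for Trifluoromethoxy on the Sulfonyl Ring

This account rests on a few compounds, and the source may have more. Where it says the series, first, only, none or still open, it means among the compounds named here.

Of the compounds shown here, three sharing one core have been measured in a functional assay on HCC1806 cells (Homo sapiens) for inhibition, read by sulforhodamine B assay, tested at 10 uM; a higher number here means more inhibition at the concentration tested (going by the name of the read-out), a lower number less inhibition. Compound 1 `CN(C)c1ccc(C2CC(c3ccc(-n4cncn4)cc3)=NN2S(C)(=O)=O)cc1` carries a methyl on its sulfonyl sulfur and gives 10.8%. Compound 2 `Cc1ccc(S(=O)(=O)N2N=C(c3ccc(-n4cncn4)cc3)CC2c2ccc(N(C)C)cc2)cc1` gives 27.7%, and compound 3 `CN(C)c1ccc(C2CC(c3ccc(-n4cncn4)cc3)=NN2S(=O)(=O)c2ccc(Br)cc2)cc1` gives 26.3%. Putting a 4-methylphenyl in place of that methyl produced a number 16.9 percentage points higher from compound 1 to compound 2 (beyond the scatter), and putting a 4-bromophenyl there produced a number 15.5 percentage points higher from compound 1 to compound 3 (beyond the scatter). Between the two aryl-bearing compounds the change was only a number 1.4 percentage points lower from compound 2 to compound 3 (within the scatter). Compound 3 therefore sits together with compound 2 at the higher end of the three numbers, the gap between them within the scatter, while it stands clearly above compound 1.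

Compound 4 `CN(C)c1ccc(C2CC(c3ccc(-n4cncn4)cc3)=NN2S(=O)(=O)c2ccc(OC(F)(F)F)cc2)cc1` differs from compound 3 by trifluoromethoxy in place of bromo on an aromatic carbon. Going by the values given here, the step that bears most directly on this is the one from compound 2 to compound 3, where exchanging one small group for another on the same aromatic carbon changed the read-out by a number 1.4 percentage points lower from compound 2 to compound 3 (within the scatter), within the scatter. The two steps from compound 1 show that the gain comes from having an aryl on the sulfonyl sulfur at all, which compound 4 retains. The step to compound 4 is thus expected to be a number 0.7 percentage points higher from compound 3 to compound 4 (within the scatter). Compound 4 is expected to give about 27%, most likely between 14% and 40%.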

Compound 4, a percentage reported as inhibition, at one concentration (the size of the read-out at that concentration, not a potency): 25.2%
Beside the measured number, compound 4's estimate is 1.8 percentage points above it, and the stated range covers the measured number.
By their numbers in this assay, from the lowest: compound 1; then compounds 4, 3 and 2 (each within the scatter of the next).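

In this assay, the aromatic carbon that held bromo takes trifluoromethoxy, with 5 heavy atoms where bromo has 1, and the outcome is a number 1.1 percentage points lower from compound 3 to compound 4 (within the scatter), so this much larger group leaves the read-out where it was. Against methyl at the same carbon the result is a number 2.5 percentage points lower from compound 2 to compound 4 (within the scatter), which means that methyl, bromo and trifluoromethoxy cannot be told apart at this place, while the step from the methyl on the sulfonyl sulfur, a number 14.4 percentage points higher from compound 1 to compound 4 (beyond the scatter), confirms that a third substituted phenyl there keeps the gain seen with the first two. Nothing available explains why such different groups give matching numbers.

Going by these compounds, every group tried on this carbon so far is small and carries no net charge, so it remains open whether an amine or a carboxylic acid there would also leave the read-out unchanged or would finally move it. These numbers also come from a single tested concentration, so they do not show whether compounds that match here would also match in potency.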